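A Methoxy Group on the Benzyl Arm of Compound 1

A few compounds are considered here, and "the series" means these few. Any claim that something is new, unique, unknown or untested is made for them only; others in the source may bear on it.

Compound 1 `NC(=O)C1CCN(c2nc(-c3ccccn3)nc3c2CN(Cc2ccccc2)CC3)CC1` gives 250000 nM in a physicochemical assay for solubility, read by HPLC, with a stated time of 24 h, at pH 7.4, tested at 250 uM (on this read-out lower numbers stand for lower solubility and higher numbers for higher solubility), and the two other measured numbers lie within the scatter of it: compound 2 `NC(=O)CN1CCN(c2nc(-c3ccccn3)nc3c2CN(Cc2ccccc2)CC3)CC1` gives 207000 nM and compound 3 `CN1CCN(CCCNc2nc(-c3ccccn3)nc3c2CN(Cc2ccccc2)CC3)CC1` gives 180000 nM, with steps of a 1.2-fold lower number from compound 1 to compound 2 (0.08 log units; within the scatter) and a 1.4-fold lower number from compound 1 to compound 3 (0.14 log units; within the scatter). Compound 4 `COc1ccc(CN2CCc3nc(-c4ccccn4)nc(N4CCC(C(N)=O)CC4)c3C2)cc1` differs from compound 1 in one place: methoxy in place of hydrogen on an aromatic carbon. Every measured step instead swaps the group on an aromatic carbon of the shared core, leaving the benzyl untouched, and each stayed within the scatter. Going by the values given here, no measured step therefore bears directly on this change, and no movement beyond the scatter is expected in this assay. Compound 4 is expected to give about 220000 nM, within 120000 nM to 250000 nM, an expected step of a 1.1-fold lower number from compound 1 to compound 4 (0.06 log units; within the scatter).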

Compound 4, solubility: 224000 nM
Compound 4: middle estimate off by 1.0-fold (0.01 log units), on the low side; the measured number falls inside the stated range.
By their numbers in this assay, from the lowest: compounds 3, 2, 4 and 1 (each within the scatter of the next).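

Changing benzyl to 4-methoxybenzyl gives a 1.1-fold lower number from compound 1 to compound 4 (0.05 log units; within the scatter) in this assay, the first step shown on the benzyl arm rather than on the group attached to the shared core. It shows that this phenyl ring can carry a methoxy, para to a large group, without a movement beyond the scatter on this read-out. Nothing available gives a reason for this result. Still open, from the compounds shown here alone, is whether a carboxylic acid or an amine in place of the methoxy would also stay within the scatter of compound 1.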